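Two limits and an open compound in one series

A few compounds are considered here, and "the series" means these few. Any claim that something is new, unique, unknown or untested is made for them only; others in the source may bear on it.

Measured so far, in a functional assay on HCT-116 cells (Homo sapiens) for antiproliferative activity, read by MTT assay, with a stated time of 48 h; on this read-out lower numbers stand for stronger inhibition of growth and higher numbers for weaker inhibition of growth:
Compound 1 `Cc1ccc(C2=NN(C(=S)Nc3ccccc3)C(c3ccc4c(c3)OCCO4)C2)cc1` gives > 200000 nM, a limit of the assay.
Compound 2 `O=[N+]([O-])c1ccc(C2=NN(C(=S)Nc3ccccc3)C(c3ccc4c(c3)OCCO4)C2)cc1` gives > 200000 nM, also a limit of the assay.

Among the measured compounds shown here, the one measured step, a step that the two limits leave unreadable from compound 1 to compound 2, cannot be read in size because both ends are limits. Compound 2 therefore stands only at the limit; the limit of > 200000 nM in this assay, at which 2 of the 2 values shown sit, describes where both values sit, and nothing in this assay separates compound 2 from compound 1.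

Compound 3 `S=C(Nc1ccccc1)N1N=C(c2ccccc2Br)CC1c1ccc2c(c1)OCCO2` differs from compound 2 by 2-bromophenyl in place of 4-nitrophenyl on a carbon with a double bond to nitrogen. For the measured compounds named here, no measured step bears on this change in a readable way, so no direction or size can be taken from the data; the only guide is that both values so far are limits. Compound 3 is expected to remain at or near that limit, with an estimated step that the limit leaves unreadable from compound 2 to compound 3, giving an estimate of 250000 nM within the range 100000 nM to 600000 nM.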

Compound 3, concentration for 50% growth inhibition: 195000 nM
For compound 3 the middle estimate is 1.3-fold (0.11 log units) above the measured one; the measured number falls inside the stated range.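

In this assay, among the compounds shown here, compound 3 gives 195000 nM, the first value that is a number and not a limit of the assay, so 2-bromophenyl on this carbon with a double bond to nitrogen brings the series into the readable range. The change from 4-nitrophenyl gives an at least 1.0-fold lower number from compound 2 to compound 3 (0.01 log units; that floor lies within the scatter), and the change from 4-methylphenyl gives an at least 1.0-fold lower number from compound 1 to compound 3 (0.01 log units; that floor lies within the scatter). Both steps start from a limit of the assay, so they give floors only and no true size, and growth inhibition remains weak across all three aryl groups at this position: the limit of > 200000 nM in this assay, at which 2 of the 3 values shown sit.

Open, from the compounds shown here alone, is whether 4-bromophenyl would read as 2-bromophenyl does, or whether an amine or a carboxylic acid on this phenyl ring would move the value far from this level. Going by these compounds, the effect of replacing the 2,3-dihydro-1,4-benzodioxin-6-yl group or the group of 9 heavy atoms on the ring nitrogen is also open.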